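Replacing the bromophenyl of a cytotoxic chalcone

A few compounds are considered here, and "the series" means these few. Any claim that something is new, unique, unknown or untested is made for them only; others in the source may bear on it.

Measured compounds:
compound 1 `O=C(/C=C/c1cccc(OCc2ccccc2)c1)c1ccccc1Br`: 2200 nM
compound 2 `O=C(/C=C/c1cccc(OCc2ccccc2)c1)c1cccc(Br)c1`: 7100 nM
compound 3 `O=C(/C=C/c1cccc(OCc2ccccc2)c1)c1ccc([N+](=O)[O-])cc1`: 59300 nM

These three share a core and differ only in the ring on the carbonyl carbon. In an ADME assay on HEK293 cells (Homo sapiens) for cytotoxicity, read by MTT assay, with a stated time of 68 h (a lower number here means a stronger inhibitor, a higher number a weaker inhibitor), compound 1 gives the lowest of the three numbers. The nearest is compound 2, reached by a 3.2-fold higher number from compound 1 to compound 2 (0.51 log units; beyond the scatter). The furthest is compound 3, reached by a 27-fold higher number from compound 1 to compound 3 (1.43 log units; beyond the scatter); compound 2 to compound 3 is an 8.4-fold higher number from compound 2 to compound 3 (0.92 log units; beyond the scatter).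

Compound 4 `O=C(/C=C/c1cccc(OCc2ccccc2)c1)c1ccc(Cl)cc1` has not yet been measured. It differs from compound 1 as follows: 4-chlorophenyl in place of 2-bromophenyl on a carbonyl carbon. Among the measured compounds shown here, two measured steps bear on this change. Moving the bromine within the ring, from compound 1 to compound 2, already raised the number beyond the scatter, and the 4-nitrophenyl of compound 3 raised it much further. A 4-chlorophenyl shares the substitution pattern of compound 3 but the halogen character of compounds 1 and 2, so a step upward from compound 1 of intermediate size is expected, a 4.5-fold higher number from compound 1 to compound 4 (0.66 log units; beyond the scatter). Compound 4 is therefore estimated at 10000 nM, with a range from 3000 nM to 35000 nM.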

Compound 4, half-maximal inhibitory concentration: 22800 nM
For compound 4 the middle estimate is 2.3-fold (0.36 log units) below the measured one; the range from low to high includes it.
By their numbers in this assay, from the lowest: compound 1; then compound 2; then compound 4; then compound 3.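

Replacing the 2-bromophenyl with the 4-chlorophenyl gives a large step (a 10-fold higher number from compound 1 to compound 4 (1.02 log units; beyond the scatter)), and this change alters both the halogen and its place on the ring, so the two effects cannot be separated here. The 4-chlorophenyl also gives a higher number than the 3-bromophenyl (a 3.2-fold higher number from compound 2 to compound 4 (0.51 log units; beyond the scatter)), so having a halogen on the ring does not by itself keep the number near that of compound 1. With the substitution pattern held the same, chloro in place of nitro still moves the number beyond the scatter (a 2.6-fold lower number from compound 3 to compound 4 (0.42 log units; beyond the scatter)), which shows that the identity of the group matters and not only where it sits.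

Nothing available explains these steps. Still open, going by these compounds, are whether chlorine and bromine differ when they sit at the same place on the ring, and how an amine or a carboxylic acid there would compare.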